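The source may report more compounds than this note shows. Statements on the series, on what has been measured and on what is new or still open speak of the compounds shown alone.

Of the compounds shown here, two built on one shared core have been tested in a functional assay on HeLa cells (Homo sapiens) for inhibition, read by sulforhodamine B assay; a higher number here means a weaker inhibitor, a lower number a stronger inhibitor. Compound 1 `O=C1C=C(NCc2ccccc2)C(=O)c2c1nc1n2[C@H]2OC[C@@H](O)[C@H]2OC1` carries a benzyl group on its amine nitrogen. In this assay compound 1 gives > 8000 nM, which is a limit of the assay rather than a measured number. Where compound 1 stands is thus known only as a boundary: the limit of > 8000 nM in this assay, at which 1 of the 2 values shown sits. Compound 2 `O=C1C(Nc2ccc(C(F)(F)F)cc2)=CC(=O)c2c1nc1n2[C@H]2OC[C@@H](O)[C@H]2OC1` carries a trifluoromethyl-bearing phenyl ring on the same nitrogen, and in this assay compound 2 gives 8920 nM, a weak inhibition. Among the measured compounds shown here, no step between two measured compounds is available, so the two values can only be set side by side, and both sit in the weak region.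

Compound 3 `COc1cccc(NC2=CC(=O)c3nc4n(c3C2=O)[C@H]2OC[C@@H](O)[C@H]2OC4)c1` differs from compound 1 in one place: 3-methoxyphenyl in place of benzyl on an amine nitrogen. Compound 2, which also carries a phenyl ring on that nitrogen, gives 8920 nM, and compound 3 is expected to behave in a similar way. The step that the limit leaves unreadable from compound 1 to compound 3 is expected to stay within the usual scatter. Compound 3 is therefore expected to give about 8500 nM, within a range from 3000 nM to 25000 nM, and it may again return only a limit.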

Compound 3, half-maximal inhibitory concentration: 4280 nM
For compound 3 the middle estimate is 2.0-fold (0.30 log units) above the measured one, within the range that was stated.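

In this assay compound 3, with 3-methoxyphenyl in place of benzyl on the amine nitrogen, gives 4280 nM, so this nitrogen now has a substituent with a measured number and not only a boundary. The change gives an at least 1.8-fold lower number from compound 1 to compound 3 (0.27 log units; that floor lies within the scatter), so the data show no firm gain in potency, although a larger true step is not excluded. Only this floor can be read, because the value for compound 1 is a limit of the assay and not a number: the limit of > 8000 nM in this assay, at which 1 of the 3 values shown sits.

The compounds shown leave open which part of the change matters, since the benzyl group's linking carbon leaves and the methoxy group enters in the same step. A plain phenyl group or a 3-methoxybenzyl group on this nitrogen would separate these two parts, while a carboxylic acid or an amine on the aromatic ring in place of the methoxy group would test whether the number in this assay responds to what that ring carries.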